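Phenyl addition on the amide-bearing ring in two cores

The source may hold more compounds than are shown below. What is called first, only, known or untested is meant among the compounds shown, and "the series" means these compounds.

Compound 1 `Nc1ccccc1NC(=O)C1(S(=O)(=O)c2ccc(Oc3ccc(OC(F)(F)F)cc3)cc2)CCC2(CCNCC2)C1` and compound 2 `Nc1ccc(-c2ccccc2)cc1NC(=O)C1(S(=O)(=O)c2ccc(Oc3ccc(OC(F)(F)F)cc3)cc2)CCC2(CCNCC2)C1` share one core; compound 3 `COc1ccc(S(=O)(=O)C2(C(=O)Nc3ccccc3N)CCC3(CCNCC3)C2)cc1Cl` and compound 4 `COc1ccc(S(=O)(=O)C2(C(=O)Nc3cc(-c4ccccc4)ccc3N)CCC3(CCNCC3)C2)cc1Cl` share another. The difference between the two cores is not broken down here. In a functional assay on blood (Homo sapiens), with a stated time of 60 min, in the presence of a further agent that is not named here (on this read-out higher numbers stand for an effect only at larger amounts of compound and lower numbers for an effect already at smaller amounts), compound 1 gives 900 nM. For compound 2 the value in this assay is a limit of the assay, <= 400 nM. The step of an at least 2.2-fold lower number from compound 1 to compound 2 (0.35 log units; beyond the scatter) comes with the change (phenyl in place of hydrogen on an aromatic carbon). Because compound 2 sits at the limit of <= 400 nM in this assay, at which 1 of the 3 values shown sits, the size of that step is known only as a lower bound.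

Compound 3 gives 7500 nM in this assay, the higher of the two numbers shown and well above the number for compound 1. The change from compound 3 to compound 4 is phenyl in place of hydrogen on an aromatic carbon, the same change as before, at a place described in the same words.

The step from compound 3 to compound 4 in this assay is expected to be a 3.0-fold lower number from compound 3 to compound 4 (0.48 log units; beyond the scatter), resting on the measured step of an at least 2.2-fold lower number from compound 1 to compound 2 (0.35 log units; beyond the scatter), which gives only a floor for the gain, so a somewhat larger drop is taken as the middle of the expectation. Compound 4 is therefore expected to give about 2500 nM in this assay, with 800 nM to 6000 nM as the expected range.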

Compound 4, half-maximal effective concentration: 15000 nM
The estimate for compound 4 lay 6.0-fold (0.78 log units) below the measured number, and the stated range ends below it.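

On the core of compound 3, phenyl in place of hydrogen on an aromatic carbon gives a 2.0-fold higher number from compound 3 to compound 4 (0.30 log units; within the scatter) in this assay, so the gain seen on the core of compound 1 does not carry over to this second core: the same change on two cores in this assay, an at least 2.2-fold lower number (0.35 log units; beyond the scatter) from compound 1 to compound 2 and a 2.0-fold higher number (0.30 log units; within the scatter) from compound 3 to compound 4, at least 4.5-fold (0.65 log units) apart, beyond the scatter of two such steps. This rests on a single pair per core, and it does not show which part of the difference between the two cores goes with the split, or how the change would behave on any third core. Compound 2 stands at a limit of the assay, not at a number: the limit of <= 400 nM in this assay, at which 1 of the 4 values shown sits.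

Still open, as far as these compounds go, is whether the split is specific to phenyl, since a methyl group, a fluorine atom or a pyridine ring at the same place, para to the amino group, could behave alike on both cores or could differ as phenyl does. Also open is how the change behaves when the group on the sulfonyl is neither of the two shown, for example an unsubstituted phenyl, which would help to tie the split to one part of the core.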